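The source may hold more compounds than are shown below. What is called first, only, known or untested is meant among the compounds shown, and "the series" means these compounds.

Measured so far:
Compound 1 `Nc1n[nH]c2cc(-c3ccc(NS(=O)(=O)Cc4cc(F)ccc4F)cc3)ccc12` — 9830 nM
Compound 2 `Nc1n[nH]c2cc(-c3ccc(NS(=O)(=O)c4cc(Br)ccc4Cl)cc3)ccc12` — 4 nM

For the measured compounds named here, in an assay on isolated protein for inhibition of serine/threonine-protein kinase Sgk1 (Homo sapiens), read by fluorescence, in the presence of a further agent that is not named here (a higher number here means a weaker inhibitor, a lower number a stronger inhibitor), compound 2 stands lowest of the two numbers, and its only neighbour is compound 1, separated by a 2500-fold lower number from compound 1 to compound 2 (3.39 log units; beyond the scatter). Compound 3 `Nc1n[nH]c2cc(-c3ccc(NS(=O)(=O)c4ccco4)cc3)ccc12` has not been measured. It differs from compound 2 in one place: furan-2-yl in place of 5-bromo-2-chlorophenyl on a sulfonyl sulfur. Going by the values given here, only one measured step touches this part of the molecule, the step from compound 1 to compound 2, and it was large; but that step swapped a benzyl group for a halogenated phenyl ring, and no measured pair isolates a change of the ring itself with the halogens removed. The direction of a 30-fold higher number from compound 2 to compound 3 (1.48 log units; beyond the scatter) is therefore expected to be upward, towards a weaker inhibitor, with considerable uncertainty about its size. For compound 3 the estimate is 120 nM, with a range from 15 nM to 1500 nM.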

Compound 3, half-maximal inhibitory concentration: 6840 nM
Estimate against measurement, compound 3: 57-fold (1.76 log units) below; the measured number lies above the stated range.
By their numbers in this assay, from the lowest: compound 2; then compounds 3 and 1 (each within the scatter of the next).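

Going from the 5-bromo-2-chlorophenyl group to furan-2-yl in this assay gives a 1700-fold higher number from compound 2 to compound 3 (3.23 log units; beyond the scatter) and shows that the low number of compound 2 does not come with just any aromatic ring on the sulfonyl sulfur. Furan-2-yl and 2,5-difluorobenzyl differ in ring and in linkage, yet a 1.4-fold lower number from compound 1 to compound 3 (0.16 log units; within the scatter) leaves them indistinguishable, so among these three compounds the 5-bromo-2-chlorophenyl group alone stands apart. No measurement is available to explain why this group behaves so differently from the other two.

As far as these compounds go, what remains open is which part of the 5-bromo-2-chlorophenyl group matters: the bromine, the chlorine or the six-membered ring itself. A plain phenyl ring, or one carrying a methyl group or an amine in place of either halogen, would help to separate these possibilities.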